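Bromo in Place of Fluoro: Three Measured, One Expected

The source may hold more compounds than are shown below. What is called first, only, known or untested is meant among the compounds shown, and "the series" means these compounds.

Compound 1, `C[C@H](NC(=O)Nc1cccc(F)c1)c1ccccc1`: 88%
Compound 2, `C[C@@H](NC(=O)Nc1ccc(F)cc1)c1ccccc1`: 92%
Compound 3, `C[C@H](NC(=O)Nc1cccc(Br)c1)c1ccccc1`: 99%

These three compounds were tested in an ADME assay on the whole organism with Oryza sativa as the target, tested at 10 uM; a lower number here means a stronger effect, a higher number a weaker effect of the compound at the concentration tested. Compound 1 and compound 3 differ in a single place: bromo in place of fluoro on an aromatic carbon. That change gave a number 11 percentage points higher from compound 1 to compound 3 (beyond the scatter). Compound 2 is built from the same atoms as compound 1, joined differently; the difference between the two cores is not broken down here. In this assay compound 2 gives a value that lies within the usual scatter of compound 1 and also within the usual scatter of compound 3, so no order among them can be claimed.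

Compound 4, `C[C@@H](NC(=O)Nc1ccc(Br)cc1)c1ccccc1`, has not yet been measured. It differs from compound 2 in one place: bromo in place of fluoro on an aromatic carbon. This is the same kind of change as from compound 1 to compound 3, but the place is not identical: in compound 3 the bromo sits meta to a large group, while in compound 4 it sits para to a large group.

From compound 2 to compound 4 a step of about a number 6 percentage points higher from compound 2 to compound 4 (within the scatter) is expected, because a number 11 percentage points higher from compound 1 to compound 3 (beyond the scatter) with the same kind of change. For compound 4 the expected value is 98%, estimated to fall between 88% and 104%.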

Compound 4, a percentage reported as activity, at one concentration (the size of the read-out at that concentration, not a potency): 87%
Compound 4: middle estimate off by 11 percentage points, on the high side, and the stated range ends above it.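

In this assay, putting bromo in place of fluoro on the core of compound 2 gave a number 5 percentage points lower from compound 2 to compound 4 (within the scatter) and so, taken alone, this step cannot be told apart from repeat scatter. The result does not show why the outcome depends on the core, since the two cores differ in how their atoms are joined and a single pair on each core cannot single out which feature matters, nor can it predict the step on a further core. What it does show is that, within these four compounds, the step seen on one core was not a reliable guide to the step on the other: the same change on two cores in this assay, a number 11 percentage points higher (beyond the scatter) from compound 1 to compound 3 and a number 5 percentage points lower (within the scatter) from compound 2 to compound 4, 16 percentage points apart, beyond the scatter of two such steps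

The compounds shown carry only fluoro or bromo on that aromatic ring, so it remains open how a chloro group, a methoxy group or a carboxylic acid would read in this assay on either core. Going by these compounds, whether an amine in that place would give matching steps on the two cores also stays open.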